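The source may hold more compounds than are shown below. What is called first, only, known or untested is meant among the compounds shown, and "the series" means these compounds.

Compound 1 `O[C@@H]1Cc2ccccc2[C@H]1NC1CCN(CCCc2c[nH]c3ccc(-n4cnnc4)cc23)CC1` gives 75% in a functional assay on CHO cells for activation of 5-hydroxytryptamine receptor 1D (Homo sapiens), read by GTPgammaS binding; on this read-out lower numbers stand for smaller maximal responses and higher numbers for larger maximal responses. Compound 2 `CC(=O)Nc1ccc(CNC2CCN(CCCc3c[nH]c4ccc(-n5cnnc5)cc34)CC2)cc1` gives 75% in this assay.

Compound 1 stands level with compound 2 in this assay; the step of no change at the digits printed from compound 1 to compound 2 (within the scatter) shows that swapping the group on the amine nitrogen left the efficacy unchanged. Compound 3 `CN(Cc1ccsc1)C1CCN(CCCc2c[nH]c3ccc(-n4cnnc4)cc23)CC1` is not yet measured; it differs from compound 1 as follows: methyl((thiophen-3-yl)methyl)amino in place of (2-hydroxy-2,3-dihydro-1H-inden-1-yl)amino on a saturated ring carbon. That single measured step bears on the new one and was within the scatter, so no change beyond the scatter is expected in this assay, a step of no change at the digits printed from compound 1 to compound 3 (within the scatter). Compound 3 is therefore estimated at 75%, with a range from 55% to 95%.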

Compound 3, largest response reached (reported as efficacy), in percent of the reference or control that the assay uses: 93%
Compound 3: middle estimate off by 18 percentage points, on the low side; measured number inside the range.
By their numbers in this assay, from the lowest: compounds 1 and 2 (each within the scatter of the next); then compound 3.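

In this assay the group on this saturated ring carbon does affect the maximal response: the change gives a number 18 percentage points higher from compound 1 to compound 3 (beyond the scatter) and so goes beyond the scatter, unlike the earlier swap between compounds 1 and 2. The step replaces the hydroxylated bicyclic group with a methylated nitrogen bearing a thiophen-3-ylmethyl group, so several features change at once. No measurement available here explains the rise. On these data alone, it remains open whether the methyl or the thiophene ring accounts for the step. The (thiophen-3-yl)methylamino group without the methyl, or a benzyl(methyl)amino group, would separate the two.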